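The source may hold more compounds than are shown below. What is called first, only, known or untested is meant among the compounds shown, and "the series" means these compounds.

Compound 1 `COc1cc(N)c(Cl)cc1NC(=O)C1CCN(CC2CC2)CC1` gives > 10 mg/kg in a functional assay on the whole organism for antagonist activity, with Mus musculus as the target; a higher number here means that more compound is needed for the effect, a lower number that less compound is needed.
Compound 2 `COc1cc(N)c(Cl)cc1NC(=O)C1CCN(Cc2ccccc2)CC1` gives 0.5 mg/kg in this assay.
Compound 3 `CCCCCN1CCC(C(=O)Nc2cc(Cl)c(N)cc2OC)CC1` gives > 10 mg/kg in this assay.

Compound 3 stands at a limit of this assay rather than at a number, and it shares this limit with compound 1 (the limit of > 10 mg/kg in this assay, at which 2 of the 3 values shown sit). Compound 4 `CCC(CC)CN1CCC(C(=O)Nc2cc(Cl)c(N)cc2OC)CC1` has not yet been measured. It differs from compound 3 in one place: pentan-3-yl in place of butyl on a saturated chain carbon bound to an amine nitrogen in a ring. Within the data shown here, two measured steps touch the same place. The step of an at least 20-fold higher number from compound 2 to compound 3 (1.30 log units; beyond the scatter) was large, the step of an at least 20-fold lower number from compound 1 to compound 2 (1.30 log units; beyond the scatter) was large in the other direction, and the step that the two limits leave unreadable from compound 1 to compound 3 cannot be read. Among the measured compounds shown here, no measured step compares two open chains with each other, so the change from butyl to pentan-3-yl has no direct precedent here. Compound 4 is expected to stay near the limit, with an estimated step that the limit leaves unreadable from compound 3 to compound 4. The estimate for compound 4 is 15 mg/kg, ranging from 3 mg/kg to 60 mg/kg.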

Compound 4, dose for half-maximal effect: > 10 mg/kg
Compound 4: no number, only a limit; the forecaster's own chance of this, stated with the estimate: 70%; the middle value lies beyond the limit too.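

So far, only the straight chain of compound 3 and the cyclopropyl group of compound 1 had reached the limit, and the result for compound 4 in this assay adds a branched open chain, 2-ethylbutyl, to them: the limit of > 10 mg/kg in this assay, at which 3 of the 4 values shown sit.

Against the phenyl group, the new chain gives an at least 20-fold higher number from compound 2 to compound 4 (1.30 log units; beyond the scatter). The steps among compound 1, compound 3 and compound 4 cannot be read.

Going by these compounds, it remains open whether a pyridine ring in place of the phenyl would also give a measurable dose. A longer chain carrying the phenyl is equally untested by these compounds.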